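Working notes: three cytotoxicity limits and one open compound

The source may hold more compounds than are shown below. What is called first, only, known or untested is meant among the compounds shown, and "the series" means these compounds.

compound 1 `C=CC1=C(C(=O)NCC(C)C)C(c2ccc(F)cc2)OC1` — > 100000 nM
compound 2 `C=CC1=C(C(=O)NCC(C)C)C(c2ccc(Cl)c(Cl)c2)OC1` — > 100000 nM
compound 3 `C=CC1=C(C(=O)NC2CCCCC2)C(c2ccc(OC)c(OC)c2)OC1` — > 100000 nM

In a functional assay on A549 cells (Homo sapiens) for cytotoxicity, read by MTT assay, with a stated time of 24 h (a higher number here means a weaker inhibitor, a lower number a stronger inhibitor), compound 1 gives > 100000 nM, which is a limit of the assay and not a number. Compound 2 gives > 100000 nM in this assay, again a limit. Compound 3 gives > 100000 nM in this assay, also a limit. Compound 2 therefore stands nowhere in particular among the numbers shown: it sits at the same limit as the other two, and every value shown so far is a limit (the limit of > 100000 nM in this assay, at which 3 of the 3 values shown sit). For the measured compounds named here, no pair of measured compounds differs in one place only, so no measured step is available, and of each pair only two limits can be stated.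

Compound 4 `C=CC1=C(C(=O)NCc2ccccc2)C(c2ccc(Cl)c(Cl)c2)OC1` differs from compound 2 by phenyl in place of isopropyl on a saturated chain carbon bound to an amide-type nitrogen. Going by the values given here, nothing among the measured compounds points to a shift in this assay, so the step that the limit leaves unreadable from compound 2 to compound 4 is expected to be none beyond the scatter. Compound 4 is estimated at 150000 nM, with a range from 40000 nM to 600000 nM, and is expected most likely to be reported once more as a limit rather than as a number.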

Compound 4, half-maximal inhibitory concentration: > 100000 nM
Compound 4: no number, only a limit; the forecaster's own chance of this, stated with the estimate: 85%; the middle value lies beyond the limit too.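

In this assay compound 4 gives > 100000 nM, again a limit of the assay and not a number. For the compounds shown here, compound 2 stands at a limit as well, and no step between compound 2 and compound 4 can be read. The compounds shown leave open whether phenyl in place of isopropyl changes anything in this assay, and whether any compound of the series reaches a measurable value there.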